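Swapping a methyl for pyridin-4-yl on a carbonyl carbon

The compounds below may be only part of what the source reports. "The series", "measured", "known", "first", "only" and "open" are said of these compounds alone.

Measured so far:
- compound 1 `CN(C)CCNc1cc2c(cn1)cc(NC(=O)/C=C/c1ccccc1)c(=O)n2C` gives 27400 nM
- compound 2 `CC(=O)Nc1cc2cnc(NCCN(C)C)cc2n(C)c1=O` gives > 100000 nM, a limit and not a number
- compound 3 `CN(C)CCNc1cc2c(cn1)cc(NC(=O)c1cccc(-c3ccccc3)c1)c(=O)n2C` gives 1930 nM

All three values come from a functional assay on MCF7 cells (Homo sapiens) for antiproliferative activity, read by MTT assay, with a stated time of 48 h; on this read-out lower numbers stand for stronger inhibition and higher numbers for weaker inhibition. Compound 2 has no exact value and stands at the limit of > 100000 nM in this assay, at which 1 of the 3 values shown sits.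

Compound 4 `CN(C)CCNc1cc2c(cn1)cc(NC(=O)c1ccncc1)c(=O)n2C` has not been measured yet. It differs from compound 2 by one change: pyridin-4-yl in place of methyl on a carbonyl carbon. In short, pyridin-4-yl takes the place of methyl on a carbonyl carbon.

Among the compounds with values here, one measured step touches this same place, and it runs the opposite way. From the compounds shown here alone, it is an at least 3.6-fold higher number from compound 1 to compound 2 (0.56 log units; beyond the scatter), and it ends in a limit, so its full size is unknown. Compound 3, with a different group on that carbonyl, gives 1930 nM. Only the methyl compound of these three ends in a limit. Putting a ring-bearing group back in place of methyl is therefore expected to lower the number, as the reverse of the step to compound 2 suggests, but compound 4 could still reach the limit.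

An expected change of modest size is an at least 2.8-fold lower number from compound 2 to compound 4 (0.45 log units; beyond the scatter). The estimate for compound 4 is 35000 nM, with an expected range of 10000 nM to 100000 nM.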

Compound 4, half-maximal inhibitory concentration: 36600 nM
Compound 4: the middle estimate sits 1.0-fold (0.02 log units) below what was measured; measured number inside the range.
By their numbers in this assay, from the lowest: compound 3; then compounds 1 and 4 (each within the scatter of the next). At a limit, above all of these: compound 2.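

In this assay, replacing methyl on the carbonyl carbon with a single aromatic ring, pyridin-4-yl, is enough to give a measurable number: an at least 2.7-fold lower number from compound 2 to compound 4 (0.43 log units; beyond the scatter). The earlier step at this place involved only 2-phenylethenyl, and pyridin-4-yl now proves no different from it in this assay, so the two groups cannot be told apart here: a 1.3-fold higher number from compound 1 to compound 4 (0.13 log units; within the scatter). Compound 2 has only a limit and not an exact number, so the true size of the step away from methyl remains unknown: the limit of > 100000 nM in this assay, at which 1 of the 4 values shown sits.

Compound 3 gives 1930 nM, so a lower number is possible with a different group on this carbonyl, but the compounds shown do not reveal which feature of that group matters. A plain phenyl group on the carbonyl would show whether the ring nitrogen of pyridin-4-yl plays any part, and a saturated ring such as piperidin-4-yl would show whether the ring needs to be aromatic at all.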